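Working notes: a methoxy added to compound 3

The source may hold more compounds than are shown below. What is called first, only, known or untested is meant among the compounds shown, and "the series" means these compounds.

In a functional assay on MCF7 cells (Homo sapiens) for antiproliferative activity, read by sulforhodamine B assay, with a stated time of 48 h (on this read-out lower numbers stand for stronger inhibition and higher numbers for weaker inhibition), compound 1 (`COc1ccc(/C=C/C(=O)c2ccccc2-c2ccc(F)cc2)cc1OC`) gives 240 nM and compound 2 (`COc1ccc(/C=C/C(=O)c2ccccc2-c2cccnc2)cc1`) gives 830 nM on the same cells. Compound 3 (`COc1ccc(CNC(=O)c2ccccc2-c2ccc(F)cc2)cc1`) gives > 50000 nM as a limit of the assay, not a number. Within the data shown here, compound 3 is thus the only compound at that limit (the limit of > 50000 nM in this assay, at which 1 of the 3 values shown sits).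

Compound 4 (`COc1ccc(CNC(=O)c2ccccc2-c2ccc(F)cc2)cc1OC`) arises from compound 3 by a single change (methoxy in place of hydrogen on an aromatic carbon): methoxy in place of hydrogen on an aromatic carbon, ortho to a methoxy group and meta to a large group. Among the measured compounds shown here, no measured pair isolates this change. Compound 1 and compound 2 each differ from compound 3 in more than one place, so their values do not size it.

The expectation therefore starts from compound 3 and its limit (> 50000 nM) and assumes that one added methoxy will not move the compound far. A small gain in inhibition is expected in this assay, perhaps none beyond the scatter, and the assay may again report only a limit. The expected size of the change is an estimated at least 1.2-fold lower number from compound 3 to compound 4 (0.09 log units; that floor lies within the scatter) in this direction. The estimate for compound 4 is 40000 nM with an expected range from 10000 nM to 100000 nM on this read-out.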

Compound 4, half-maximal inhibitory concentration: > 50000 nM
Compound 4: only a limit was reported (the forecaster's own chance of this, stated with the estimate: 65%); middle value at least 1.2-fold (0.09 log units) away from the limit.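

In this assay compound 3 gives > 50000 nM, a limit of the assay. Compound 4 gives > 50000 nM, also a limit, so no step can be read between compound 3 and compound 4: the limit of > 50000 nM in this assay, at which 2 of the 4 values shown sit.

The compounds shown leave open whether methoxy in place of hydrogen on an aromatic carbon changes the value at all in this pair.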